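This account rests on a few compounds, and the source may have more. Where it says the series, first, only, none or still open, it means among the compounds named here.

Compound 3 `COc1ccc(-c2ccc3c(NCCCNCc4ccco4)ccnc3c2)cc1` carries a (furan-2-yl)methyl group on the amine. In an ADME assay for permeability, using PAMPA, with a stated time of 30 min, at pH 7.4 (a higher number here means that the compound crosses the layer faster, a lower number that the compound crosses the layer more slowly), compound 3 gives 237 10^-6 cm/s, the highest of the three numbers recorded so far. Compound 1 `COc1ccc(F)cc1CNCCCNc1ccnc2cc(Cc3ccc(C#N)cc3)ccc12` gives 23 10^-6 cm/s in this assay, and compound 2 `CCC(CC)c1ccc2c(NCCCNCc3cc(F)ccc3OC)ccnc2c1` gives 23 10^-6 cm/s; both stand under compound 3 by a gap that is beyond the scatter, and the two of them sit within the scatter of each other. Among the measured compounds shown here, the only measured step, no change at the digits printed from compound 1 to compound 2 (within the scatter), swaps a group on the aromatic core and does not touch the amine side, so it says nothing directly about the change now in question.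

Compound 4 `COc1ccc(-c2ccc3c(NCCCNCc4cc(F)ccc4OC)ccnc3c2)cc1` differs from compound 3 only in 5-fluoro-2-methoxyphenyl in place of furan-2-yl on a saturated chain carbon bound to an amine nitrogen. For the measured compounds named here, no measured pair isolates this change. What the data do show is that compound 1 and compound 2, which both carry the 5-fluoro-2-methoxybenzyl group, each give a number under compound 3 by a gap beyond the scatter, but they also differ from compound 3 elsewhere on the core, so the two effects cannot be separated. For compound 4 the expectation is therefore a downward step, a 2.4-fold lower number from compound 3 to compound 4 (0.37 log units; beyond the scatter), of uncertain size. Compound 4 is estimated at 100 10^-6 cm/s in this assay, within a range from 25 10^-6 cm/s to 300 10^-6 cm/s.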

Compound 4, apparent permeability: 237 10^-6 cm/s
For compound 4 the middle estimate is 2.4-fold (0.37 log units) below the measured one; low and high end bracket the measured number.
By their numbers in this assay, from the lowest: compounds 1 and 2 (each within the scatter of the next); then compounds 3 and 4 (each within the scatter of the next).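

In this assay, 5-fluoro-2-methoxyphenyl in place of furan-2-yl on a saturated chain carbon bound to an amine nitrogen gives no change at the digits printed from compound 3 to compound 4 (within the scatter), so with 4-methoxyphenyl on the core, this exchange of a five-membered aromatic ring for a larger six-membered one leaves the number unmoved. With the 5-fluoro-2-methoxybenzyl group held constant, 4-methoxyphenyl in place of pentan-3-yl on an aromatic carbon gives a 10-fold higher number from compound 2 to compound 4 (1.01 log units; beyond the scatter), and 4-methoxyphenyl in place of 4-cyanobenzyl on an aromatic carbon gives a 10-fold higher number from compound 1 to compound 4 (1.01 log units; beyond the scatter), so among these compounds the large steps go with the change on the aromatic carbon and not with the change on the amine side. Nothing in hand measures a property that would account for either result.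

Going by these compounds, the flat step on the amine side rests on a single pair with a single core, so it remains open whether the same exchange stays as flat with pentan-3-yl or 4-cyanobenzyl on the core. Also open, on these data alone, is how the number responds to a group of another kind on the chain carbon, such as a carboxylic acid or a morpholine ring, or to a longer chain.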